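Nitro in place of pyrrolidin-1-yl: a small expected step

The source may report more compounds than this note shows. Statements on the series, on what has been measured and on what is new or still open speak of the compounds shown alone.

In a functional assay for inhibition (on this read-out higher numbers stand for weaker inhibition and lower numbers for stronger inhibition), three compounds have been measured so far, and their numbers lie close together. Compound 1 `O=S(=O)(Nc1cc(F)c(O)c(F)c1)c1ccc(N2CCCC2)cc1` reads 97100 nM in this test, compound 2 `COc1ccc(C(=O)Nc2ccc(S(=O)(=O)Nc3cc(F)c(O)c(F)c3)cc2)cc1` reads 70700 nM in the same test, and compound 3 `Nc1ccc(S(=O)(=O)N(Cc2ccc(Br)cc2F)c2cc(F)c(O)c(F)c2)cc1` reads 73100 nM there. Compound 1 thus stands within the scatter of both others, and the numbers give no order among the three. No two of these compounds differ in one place only, so no single structural change has yet been measured directly.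

The next compound, compound 4 `O=[N+]([O-])c1ccc(S(=O)(=O)Nc2cc(F)c(O)c(F)c2)cc1`, keeps the core of compound 1 and carries nitro in place of pyrrolidin-1-yl on an aromatic carbon. Among the compounds with values here, the only guide is that compound 2 (70700 nM) and compound 3 (73100 nM) differ in structure from compound 1 yet remain within the scatter of it. Within the data shown here, on that basis, no step beyond the scatter is expected in this assay in either direction, although the data hold no measured example of nitro on this core. The estimated change is a 1.4-fold lower number from compound 1 to compound 4 (0.14 log units; within the scatter) and so stays within the scatter. Compound 4 is expected to read 70000 nM (estimated range 25000 nM to 200000 nM).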

Compound 4, half-maximal inhibitory concentration: 45700 nM
The estimate for compound 4 lay 1.5-fold (0.19 log units) above the measured number; low and high end bracket the measured number.
By their numbers in this assay, from the lowest: compounds 4, 2, 3 and 1 (each within the scatter of the next, the first and the last beyond it).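

Within the data shown here, with this pair, a single structural change can be read for the first time: in this assay, nitro in place of pyrrolidin-1-yl on an aromatic carbon, para to a large group, gives a 2.1-fold lower number from compound 1 to compound 4 (0.33 log units; beyond the scatter). The step is modest, but it lies beyond the scatter, so the group at this position does register in the read-out, which the three earlier compounds could not show because no two of them differed in one place only. No measurement of any property of these compounds accompanies the result, so nothing here accounts for the step.

From the compounds shown here alone, one pair cannot separate the loss of pyrrolidin-1-yl, with its five-membered non-aromatic ring, from the arrival of nitro, so it remains unknown which of the two carries the step. The compounds shown also leave open how a nitrile, a carboxylic acid or an open-chain group such as diethylamino would read at this position, and whether the same exchange would give a step of this size on a core carrying other changes, such as that of compound 3.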